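Ring exchange on the amide-type nitrogen: compound 3

The source may report more compounds than this note shows. Statements on the series, on what has been measured and on what is new or still open speak of the compounds shown alone.

The two measured compounds share one core and differ only in the ring attached to the amide-type nitrogen. Compound 1 `O=C(NN1CCCC1)C1=NN(c2ccc(Cl)cc2Cl)C(c2ccc(Cl)cc2)C1` carries a group of 5 heavy atoms there, and in a functional assay on the whole organism (strain Zucker) for inhibition, with Rattus norvegicus as the target, with a stated time of 4 h, at a dose of 10 mg/kg by the oral route (a higher number here means more inhibition at the dose given (going by the name of the read-out), a lower number less inhibition), compound 1 gives 2.5%. Compound 2 `O=C(NN1CC2CCCC2C1)C1=NN(c2ccc(Cl)cc2Cl)C(c2ccc(Cl)cc2)C1` carries a group of 8 heavy atoms, and in this assay compound 2 gives 3.6%. For the measured compounds named here, of the two numbers compound 2 has the higher one, yet the only measured step, a number 1.1 percentage points higher from compound 1 to compound 2 (within the scatter), lies within the scatter, so the two are not separated by this assay. Compound 3 `O=C(NN1CCCCCC1)C1=NN(c2ccc(Cl)cc2Cl)C(c2ccc(Cl)cc2)C1` is the next variation at the same place: a group of 7 heavy atoms (6 carbon, 1 nitrogen; one seven-membered non-aromatic ring with 1 hetero atom) in place of a group of 8 heavy atoms (7 carbon, 1 nitrogen; one five-membered non-aromatic ring of carbon only, one five-membered non-aromatic ring with 1 hetero atom), on an amide-type nitrogen. Going by the values given here, the single step that bears on it, a number 1.1 percentage points higher from compound 1 to compound 2 (within the scatter), shows that exchanging the ring on the amide-type nitrogen left inhibition unchanged within the scatter; both values are low. On that basis compound 3 is expected to shift by a number 0.6 percentage points lower from compound 2 to compound 3 (within the scatter), which is no step beyond the scatter. The estimate for compound 3 in this assay is 3%, with a range from -6% to 12%.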

Compound 3, a percentage reported as inhibition, in the whole organism at one dose (the size of the read-out at that dose, not a potency): 8.4%
Compound 3: the middle estimate sits 5.4 percentage points below what was measured; the measured number falls inside the stated range.
By their numbers in this assay, from the lowest: compounds 1, 2 and 3 (each within the scatter of the next).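

In this assay the azepan-1-yl group gives a number 4.8 percentage points higher from compound 2 to compound 3 (within the scatter) when it takes the place of the group of 8 heavy atoms, and a number 5.9 percentage points higher from compound 1 to compound 3 (within the scatter) when it takes the place of pyrrolidin-1-yl, so both new steps stay inside the usual spread of repeated measurements. The position on the amide-type nitrogen has now carried a five-membered ring, a group with two five-membered rings and a seven-membered ring, and no step among these three compounds is printed as beyond the scatter, so this assay does not separate them even across the widest pair, compound 1 and compound 3. No measurement is available that bears on this result or could account for any part of it.

The compounds shown all carry, at this place, rings of carbon with one nitrogen, which leaves open whether a piperidin-1-yl or a morpholin-4-yl group, with oxygen as a second hetero atom, would stand apart from them in this assay. An open-chain diethylamino group or a phenyl ring on the same nitrogen also remains an open case, since every group so far is a closed non-aromatic ring.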